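The source may hold more compounds than are shown below. What is called first, only, known or untested is meant among the compounds shown, and "the series" means these compounds.

Measured in a functional assay on HT-1080 cells (Homo sapiens) for cytotoxicity, read by MTT assay, with a stated time of 72 h; on this read-out higher numbers stand for weaker inhibition and lower numbers for stronger inhibition:
- compound 1 `COc1cccc(/C=C2\CCC/C(=C\c3ccccc3Br)C2=O)c1OC`: 10800 nM
- compound 2 `COc1cccc(/C=C2\CCC/C(=C\c3cccc(O)c3)C2=O)c1OC`: 8500 nM

Compound 2, at 8500 nM, shares its standing with compound 1, since the two values lie within the scatter of each other and neither can be ranked ahead. The next compound to be tested is compound 3 `COc1cccc(/C=C2\CCC/C(=C\c3ccc(O)cc3)C2=O)c1OC`, which differs from compound 2 at one place: 4-hydroxyphenyl in place of 3-hydroxyphenyl on a double-bonded chain carbon bound to a double-bonded ring carbon. Within the data shown here, only one measured step bears on this change, and it falls at the same place, with 3-hydroxyphenyl in place of 2-bromophenyl: a 1.3-fold lower number from compound 1 to compound 2 (0.10 log units; within the scatter). Among the measured compounds shown here, that step stayed within the scatter, and no measured compound yet carries 4-hydroxyphenyl. No shift beyond the scatter is therefore expected in this assay, and no direction is favoured. The estimated step is a 1.1-fold lower number from compound 2 to compound 3 (0.03 log units; within the scatter). For compound 3 the expected value is 8000 nM, with an estimated range of 3500 nM to 18000 nM.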

Compound 3, half-maximal inhibitory concentration: > 20000 nM
Compound 3 was reported as a limit (the forecaster's own chance of this, stated with the estimate: 5%); at least 2.5-fold (0.39 log units) between middle value and limit.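

In this assay compound 3 stands as a limit and not as a number: the limit of > 20000 nM in this assay, at which 1 of the 3 values shown sits.

Even so, putting 4-hydroxyphenyl in place of 3-hydroxyphenyl, two groups with the same atoms, gives an at least 2.3-fold higher number from compound 2 to compound 3 (0.37 log units; beyond the scatter), so this place responds to where the hydroxyl sits on the phenyl ring, which the earlier step, inside the scatter, could not show. The comparison with 2-bromophenyl is less firm, giving an at least 1.8-fold higher number from compound 1 to compound 3 (0.26 log units; that floor lies within the scatter), so that pair cannot be ranked on this floor.

From the compounds shown here alone, the true value of compound 3 stays unknown, and with it the full size of both steps. Also open, going by these compounds, is whether 2-hydroxyphenyl, 4-methoxyphenyl or 4-aminophenyl at this place would behave like compound 2 or like compound 3.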